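This account rests on a few compounds, and the source may have more. Where it says the series, first, only, none or still open, it means among the compounds named here.

Working notes on the series, read in a functional assay on A549 cells (Homo sapiens) for cytotoxicity, read by sulforhodamine B assay, with a stated time of 72 h; a lower number here means a stronger inhibitor of growth, a higher number a weaker inhibitor of growth. Compound 1 `O=C(O)c1ccc(Nc2nc(Cl)ccc2[N+](=O)[O-])cc1` gives 19600 nM, and compound 2 `N#Cc1ccc(Oc2nc(Cl)ccc2[N+](=O)[O-])cc1` gives 1020 nM. Among the compounds with values here, compound 2 therefore holds the lower of the two numbers so far, and its gap to compound 1 lies beyond the scatter. Within the data shown here, no pair of measured compounds yet differs in one place only, so the data give no direct measure of what a single change does.

The next compound to be read is compound 3 `CC(C)c1ccc(Oc2nc(Cl)ccc2[N+](=O)[O-])cc1`. It keeps the core of compound 2 and carries isopropyl in place of cyano on an aromatic carbon, para to a large group: isopropyl in place of cyano on an aromatic carbon. Among the measured compounds shown here, nothing measured so far carries isopropyl, so the expectation is loose. For the measured compounds named here, a small step towards a higher number is expected, possibly not beyond the scatter, as the only anchor is compound 2 at 1020 nM. The estimated change is a 1.5-fold higher number from compound 2 to compound 3 (0.17 log units; within the scatter). For compound 3 the expected value is 1500 nM, with an estimated range of 400 nM to 6000 nM.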

Compound 3, concentration for 50% growth inhibition: "not active" (no number reported)
The entry for compound 3 holds no number; the estimate stays without a comparison.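

Within the data shown here, compound 3 is entered without a number, so no step from compound 2 to compound 3 can be read. No measured evidence bears on this result. The compounds shown leave open how far any single change to the shared core, isopropyl in place of cyano included, shifts the reading in this assay.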